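The source may hold more compounds than are shown below. What is called first, only, known or untested is meant among the compounds shown, and "the series" means these compounds.

Measured in a functional assay on A-375 cells (Homo sapiens) for inhibition, read by CCK-8 assay, with a stated time of 72 h, tested at 8 uM; on this read-out lower numbers stand for less inhibition of growth and higher numbers for more inhibition of growth at the one concentration tested:
- compound 1 `Nc1ccccc1NC(=O)/C=C/c1ccc(CSc2cccc(F)c2)cc1`: 9.08%
- compound 2 `COc1ccc(SCc2ccc(C(=O)Nc3ccccc3N)cc2)cc1`: 81.8%
- compound 3 `CCc1ccc(SCc2ccc(C(=O)Nc3ccccc3N)cc2)cc1`: 71.1%

Of these three, compound 3 holds the middle place. It sits clearly under compound 2 and far above compound 1, whose value is much the lowest.

The next compound, compound 4 `Cc1ccc(SCc2ccc(C(=O)Nc3ccccc3N)cc2)cc1`, differs from compound 3 by hydrogen in place of methyl on a saturated chain carbon bound to an aromatic carbon. In words, this is hydrogen in place of methyl on a saturated chain carbon bound to an aromatic carbon, so that ethyl becomes methyl and 4-ethylphenyl becomes 4-methylphenyl.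

Within the data shown here, only one measured step bears on this change: a number 10.7 percentage points lower from compound 2 to compound 3 (beyond the scatter), with ethyl in place of methoxy on an aromatic carbon. Among the measured compounds shown here, that step was modest, and it is the only guide to how far such a group exchange moves this assay. The present change is small, so a step no larger than that one is expected, and its direction cannot be firmly told. The expected step is a number 3.9 percentage points higher from compound 3 to compound 4 (within the scatter), which would stay within the scatter. For compound 4 the estimated value is 75%, with an expected range of 60% to 87%.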

Compound 4, percent growth inhibition at one concentration: 67%
Estimate against measurement, compound 4: 8 percentage points above; the range from low to high includes it.
By their numbers in this assay, from the lowest: compound 1; then compounds 4 and 3 (each within the scatter of the next); then compound 2.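

In this assay the change from 4-ethylphenyl to 4-methylphenyl gives a number 4.1 percentage points lower from compound 3 to compound 4 (within the scatter) and so shows no effect that can be told apart from the scatter between these two alkyl groups. Methyl in place of methoxy gives a number 14.8 percentage points lower from compound 2 to compound 4 (beyond the scatter) and, taken with the earlier ethyl step, places both alkyl compounds under compound 2, so the methoxy compound stands apart from each of them. No measurement at hand explains this gap.

From the compounds shown here alone, how a longer chain such as propyl, an amine or a chlorine atom would read on the same aromatic carbon remains open, so the comparison of alkyl groups rests on ethyl and methyl alone. Compound 1 differs from the others in more than one place, and its low value cannot be tied to any single change.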